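Fluoro for methyl on a urea: an expected small step

The source may hold more compounds than are shown below. What is called first, only, known or untested is meant among the compounds shown, and "the series" means these compounds.

Compound 1 `Cc1ccccc1NC(=O)N[C@H](C)c1ccccc1` was tested in an ADME assay on the whole organism with Oryza sativa as the target, tested at 0.1 uM (a lower number here means a stronger effect, a higher number a weaker effect of the compound at the concentration tested), where it gives 100%. Compound 2 `Cc1ccccc1NC(=O)N[C@@H](C)c1ccccc1` has the same atoms and bonds and gives 100%, and compound 3 `C[C@H](NC(=O)Nc1cccc(C(F)(F)F)c1)c1ccccc1` gives 94%. Compound 1 thus stands level with compound 2 at the digits shown, and the two together are the highest of the three numbers; the gap to compound 3 lies within the scatter. Going by the values given here, the only measured step between neighbours, no change at the digits printed from compound 1 to compound 2 (within the scatter), is explained by the fact that compounds 1 and 2 differ only in the configuration as drawn: turning the stereocentre alone left the read-out untouched.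

Compound 4 `C[C@@H](NC(=O)Nc1ccccc1F)c1ccccc1` is the next compound to be measured. Compared with compound 1 it carries fluoro in place of methyl on an aromatic carbon, the fluoro sitting on an aromatic carbon of a six-membered aromatic ring of carbon only, ortho to a large group. Among the compounds with values here, none of the measured steps swaps one substituent for another on that ring, so no step bears directly on this change; the one step that exists was flat. On that basis no movement beyond the scatter is expected, and compound 4 is estimated at 97%, with a range from 85% to 100%, which means an expected step of a number 3 percentage points lower from compound 1 to compound 4 (within the scatter).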

Compound 4, a percentage reported as activity, at one concentration (the size of the read-out at that concentration, not a potency): 97%
Compound 4: the middle estimate sits on the measured number at the digits printed; the range from low to high includes it.
By their numbers in this assay, from the lowest: compounds 3, 4, 1 and 2 (each within the scatter of the next).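

Replacing the methyl with a fluoro, on an aromatic carbon ortho to a large group, is the first change shown at this place on the ring, and in this assay the step reads a number 3 percentage points lower from compound 1 to compound 4 (within the scatter). At this place, then, the read-out at the single concentration tested does not separate a methyl from a fluoro, although one heavy atom has been exchanged for another of a different element. This says nothing about potency, and no available information accounts for the flat step or ties it to any property of either group.

From the compounds shown here alone, it remains open whether any substituent at this place can move the number beyond the scatter, and a methoxy, a nitrile or a carboxylic acid on the same aromatic carbon would put that to the test. Going by these compounds, it is also open whether turning the stereocentre would leave the read-out as untouched with the fluoro present as it did with the methyl, and whether the close agreement would hold at a higher concentration.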